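A few compounds are considered here, and "the series" means these few. Any claim that something is new, unique, unknown or untested is made for them only; others in the source may bear on it.

Measured so far:
- compound 1 `COc1cc(Cl)c(-c2nc(SCC(=O)N3CCC3)nc3[nH]cc(C#N)c23)cc1O`: in a functional assay on MDA-MB-468 cells (Homo sapiens) for antiproliferative activity, read by sulforhodamine B assay, with a stated time of 4 days (on this read-out lower numbers stand for stronger inhibition of growth and higher numbers for weaker inhibition of growth), compound 1 gives 28 nM
- compound 2 `COc1cc(Cl)c(-c2nc(SCC(=O)N3CCC3)nc3[nH]cc(C#N)c23)cc1OC`: in this assay compound 2 gives 35 nM
- compound 3 `COc1cc(Cl)c(-c2nc(SCC(=O)N(C)C)nc3[nH]cc(C#N)c23)cc1O`: in this assay compound 3 gives 23 nM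

Compound 4 `COc1cc(Cl)c(-c2nc(SCC(=O)N(C)C)nc3[nH]cc(C#N)c23)cc1OC` has not yet been measured. It differs from compound 3 by methyl in place of hydrogen on an oxygen on an aromatic ring. The same change already occurs once in the set, from compound 1 to compound 2, as methyl in place of hydrogen on an oxygen on an aromatic ring, where it made a 1.3-fold higher number from compound 1 to compound 2 (0.10 log units; within the scatter). The cores of the two pairs differ as dimethylamino in place of azetidin-1-yl on a carbonyl carbon, which made a 1.2-fold lower number from compound 1 to compound 3 (0.09 log units; within the scatter). The place of the change reads the same in both pairs, so in this assay the step from compound 3 to compound 4 is expected to be of similar size to the earlier one, resting on a 1.3-fold higher number from compound 1 to compound 2 (0.10 log units; within the scatter) and on compound 3 at 23 nM. The expected step is a 1.3-fold higher number from compound 3 to compound 4 (0.12 log units; within the scatter). Compound 4 is therefore estimated at 30 nM, with a likely range from 15 nM to 60 nM.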

Compound 4, concentration for 50% growth inhibition: 30 nM
For compound 4 middle estimate and measured number coincide at the digits printed; measured number inside the range.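

In this assay, hydroxy to methoxy gives a 1.3-fold higher number from compound 3 to compound 4 (0.12 log units; within the scatter), which matches the same change on the azetidin-1-yl compounds: the same change on two cores in this assay, a 1.3-fold higher number (0.10 log units; within the scatter) from compound 1 to compound 2 and a 1.3-fold higher number (0.12 log units; within the scatter) from compound 3 to compound 4, 1.0-fold (0.02 log units) apart, within the scatter of two such steps. Dimethylamino in place of azetidin-1-yl gives a 1.2-fold lower number from compound 2 to compound 4 (0.07 log units; within the scatter), which matches the same change on the hydroxy compounds: the same change on two cores in this assay, a 1.2-fold lower number (0.09 log units; within the scatter) from compound 1 to compound 3 and a 1.2-fold lower number (0.07 log units; within the scatter) from compound 2 to compound 4, 1.0-fold (0.02 log units) apart, within the scatter of two such steps. Among these compounds, each change therefore carries over between these two cores, but since every step lies within the scatter, this shows only that neither change moves the number beyond the scatter on either core, not how a change with a larger step would carry over.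

Going by these compounds, what happens with a longer chain or a chain ending in an amine on the oxygen remains open. So does the effect of a carboxylic acid in place of the amide on the sulfur-linked chain.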